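Three Measured Triaryl Pyridines and an Expected Fourth

The compounds below may be only part of what the source reports. "The series", "measured", "known", "first", "only" and "open" are said of these compounds alone.

Measured so far:
Compound 1 `Cc1ccsc1-c1cc(-c2ccc(Cl)o2)cc(-c2cccc(Cl)c2)n1` gives 20500 nM in a functional assay on DU-145 cells (Homo sapiens) for cytotoxicity, read by ELISA, with a stated time of 4 days; a lower number here means a stronger inhibitor, a higher number a weaker inhibitor.
Compound 2 `Cc1ccsc1-c1cc(-c2ccc(Cl)o2)cc(-c2ccc(Cl)cc2)n1` gives 21900 nM in this assay.
Compound 3 `Clc1cccc(-c2cc(-c3ccc(Cl)o3)cc(-c3ccc(Cl)s3)n2)c1` gives 21600 nM in this assay.

All three numbers sit within the scatter of one another, so none can be called stronger or weaker. Compound 1 and compound 2 differ by one change, (4-chlorophenyl in place of 3-chlorophenyl on an aromatic carbon), and the step was a 1.1-fold higher number from compound 1 to compound 2 (0.03 log units; within the scatter). Compound 3 and compound 4 `Clc1ccc(-c2cc(-c3ccc(Cl)o3)cc(-c3ccc(Cl)s3)n2)cc1` differ by the same kind of change, (4-chlorophenyl in place of 3-chlorophenyl on an aromatic carbon), though the surroundings differ: in the first case the place is meta to a 3-methylthiophen-2-yl group, in the second meta to a 5-chlorothiophen-2-yl group. The cores of compound 1 and compound 3 differ by 5-chlorothiophen-2-yl in place of 3-methylthiophen-2-yl on an aromatic carbon, a step of a 1.1-fold higher number from compound 1 to compound 3 (0.02 log units; within the scatter).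

Since the earlier change left the number essentially unchanged, the step from compound 3 to compound 4 is expected to be a 1.1-fold higher number from compound 3 to compound 4 (0.03 log units; within the scatter). Compound 4 is therefore estimated at 23000 nM, likely between 11000 nM and 48000 nM.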

Compound 4, half-maximal inhibitory concentration: 23000 nM
For compound 4 middle estimate and measured number coincide at the digits printed, within the range that was stated.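

In this assay, putting 4-chlorophenyl in place of 3-chlorophenyl gives a 1.1-fold higher number from compound 3 to compound 4 (0.03 log units; within the scatter), and this step matches its counterpart on the other core: the same change on two cores in this assay, a 1.1-fold higher number (0.03 log units; within the scatter) from compound 1 to compound 2 and a 1.1-fold higher number (0.03 log units; within the scatter) from compound 3 to compound 4, 1.0-fold (0.00 log units) apart, within the scatter of two such steps. Putting 5-chlorothiophen-2-yl in place of 3-methylthiophen-2-yl gives a 1.1-fold higher number from compound 2 to compound 4 (0.02 log units; within the scatter), and this step also matches its counterpart: the same change on two cores in this assay, a 1.1-fold higher number (0.02 log units; within the scatter) from compound 1 to compound 3 and a 1.1-fold higher number (0.02 log units; within the scatter) from compound 2 to compound 4, 1.0-fold (0.00 log units) apart, within the scatter of two such steps. Across these four compounds, each change therefore looks the same on both cores, but only in that neither moves the number beyond the scatter on either core, so this does not show that a change with a clear effect would carry over in the same way.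

On these data alone, it remains open whether an amine or a carboxylic acid in place of the chlorine on the phenyl group would shift the number beyond the scatter. As far as these compounds go, the 5-chlorofuran-2-yl group is shared by all four compounds, so what would happen with a longer chain in its place also remains open.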